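The source may hold more compounds than are shown below. What is called first, only, known or untested is meant among the compounds shown, and "the series" means these compounds.

For the measured compounds named here, compound 1 `CNc1nc(NCCCN(C)C)c2sc(-c3ccc(C(F)(F)F)cc3)cc2n1` is the only compound with a number in a physicochemical assay for solubility, in phosphate buffer, at pH 6.5; a lower number here means a less soluble compound, a higher number a more soluble compound: compound 1 gives 177 ug/mL. Compound 2 `CNc1nc(NC(C)(C)C)c2sc(-c3ccc(C(F)(F)F)cc3)cc2n1` gives only a limit, < 1.6 ug/mL, in this assay. Going by the values given here, the single measured step, an at least 110-fold lower number from compound 1 to compound 2 (2.04 log units; beyond the scatter), replaces one nitrogen substituent with another, and compound 2 sits at the limit of < 1.6 ug/mL in this assay, at which 1 of the 2 values shown sits. Compound 3 `CN(C)CCCNc1ncnc2cc(-c3ccc(C(F)(F)F)cc3)sc12` differs from compound 1 in a different place: hydrogen in place of methylamino on an aromatic carbon. Compound 3 keeps the 3-(dimethylamino)propyl group, and the measured step between compound 1 and compound 2 changes a different group, not the methylamino group, and does not bear directly on this change. Among the compounds with values here, no measured pair shows what removing methylamino does in this assay. Within the data shown here, with no guiding step, a change no larger than the usual scatter is expected, a 1.5-fold lower number from compound 1 to compound 3 (0.17 log units; within the scatter). Compound 3 is therefore estimated at 120 ug/mL, with a range from 40 ug/mL to 350 ug/mL.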

Compound 3, solubility: 205 ug/mL
Estimate against measurement, compound 3: 1.7-fold (0.23 log units) below; low and high end bracket the measured number.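

Replacing methylamino with hydrogen on the aromatic carbon between two ring nitrogen atoms gives a 1.2-fold higher number from compound 1 to compound 3 (0.06 log units; within the scatter) in this assay and so shows no change beyond the scatter. For the compounds shown here, with the 3-(dimethylamino)propyl group kept, this pair therefore gives the first measured reading at this position, and the methylamino group is not needed here to hold the number in this assay. The one large step shown remains the exchange of 3-(dimethylamino)propyl for tert-butyl on the nitrogen, not the change at this aromatic carbon.

The compounds shown leave open what a morpholine, a carboxylic acid or a methoxy group would give at this aromatic carbon. Also open is whether hydrogen in place of methylamino would read the same with tert-butyl on the nitrogen, where compound 2 gives only a limit: the limit of < 1.6 ug/mL in this assay, at which 1 of the 3 values shown sits.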